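The compounds below may be only part of what the source reports. "The series", "measured", "known", "first", "only" and "open" are said of these compounds alone.

Measured in a physicochemical assay for lipophilicity, measured as octanol-water partition; on this read-out higher numbers stand for higher lipophilicity and lower numbers for lower lipophilicity:
- compound 1 `O=C(NNc1ccnc2cc(Cl)ccc12)c1ccccc1/N=C/c1ccc(F)cc1`: 5.18
- compound 2 `O=C(NNc1ccnc2cc(Cl)ccc12)c1ccccc1/N=C/c1ccc(Cl)c(Cl)c1`: 6.22
- compound 3 `Cc1ccc(/C=N/c2ccccc2C(=O)NNc2ccnc3cc(Cl)ccc23)cc1`: 5.31

On these numbers, compound 3 has one close neighbour and one distant one. The step of a number 0.13 log units higher from compound 1 to compound 3 (within the scatter) is small, while the step of a number 0.91 log units lower from compound 2 to compound 3 (beyond the scatter) is clearly larger.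

Compound 4 `O=C(NNc1ccnc2cc(Cl)ccc12)c1ccccc1/N=C/c1ccc([N+](=O)[O-])cc1` has nitro in place of methyl on an aromatic carbon, para to a large group (nitro in place of methyl on an aromatic carbon). Among the compounds with values here, no measured step makes this exchange. The closest is the step of a number 0.13 log units higher from compound 1 to compound 3 (within the scatter), which also swaps one group on an aromatic carbon and stays small. The step of a number 1.04 log units higher from compound 1 to compound 2 (beyond the scatter) replaces the whole 4-fluorophenyl with 3,4-dichlorophenyl, so it offers little guide here.

Nitro brings hydrogen-bond acceptors and methyl brings none, but no measured compound carries nitro, so the downward direction is tentative. The expected change in this assay is modest, and the estimated step is a number 0.31 log units lower from compound 3 to compound 4 (beyond the scatter). For compound 4 the estimate is 5, with an expected range from 4.6 to 5.4.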

Compound 4, partition coefficient: 4.58
For compound 4 the middle estimate is 0.42 log units above the measured one, and the stated range ends above it.
By their numbers in this assay, from the lowest: compound 4; then compounds 1 and 3 (each within the scatter of the next); then compound 2.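

Among the groups shown on this aromatic carbon, para to a large group, nitro is the one that clearly shifts this assay downward: nitro in place of methyl gives a number 0.73 log units lower from compound 3 to compound 4 (beyond the scatter) and nitro in place of fluoro gives a number 0.60 log units lower from compound 1 to compound 4 (beyond the scatter), whereas the exchange of fluoro and methyl stayed within the scatter. The change from 3,4-dichlorophenyl to 4-nitrophenyl gives a number 1.64 log units lower from compound 2 to compound 4 (beyond the scatter), so the aryl group on this carbon can move the read-out widely, and compound 4 now marks the low end of the series. Nothing available accounts for the size of these drops.

From the compounds shown here alone, whether the fall is particular to nitro stays open, since a nitrile, an amine or a carboxylic acid on the same carbon would be needed to show it. Also open, going by these compounds, is how nitro would behave alongside a chloro group on that ring.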